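The source may hold more compounds than are shown below. What is called first, only, known or untested is meant among the compounds shown, and "the series" means these compounds.

Compound 1 `Nc1ncnc2c1ccn2COCCO`: in a functional assay on HFF cells (Homo sapiens) for cytotoxicity (a lower number here means a stronger inhibitor, a higher number a weaker inhibitor), compound 1 gives > 100000 nM, which is a limit of the assay rather than a number.
Compound 2 `CS(=O)(=O)c1nc(N)c2ccn(COCCO)c2n1`: in this assay compound 2 gives > 100000 nM, again a limit.
Compound 3 `CC(=O)OCCOCn1ccc2c(Cl)nc(Cl)nc21`: in this assay compound 3 gives > 100000 nM, again a limit.

Among the measured compounds shown here, compound 2 therefore stands where every value so far stands, at the limit of the assay (the limit of > 100000 nM in this assay, at which 3 of the 3 values shown sit). For the measured compounds named here, the only single-point step among the measured compounds, a step that the two limits leave unreadable from compound 1 to compound 2, cannot be read, since both of its ends are limits.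

Compound 4 `Nc1nc(Cl)nc2c1ccn2COCCO` differs from compound 2 by chloro in place of methylsulfonyl on an aromatic carbon. Going by the values given here, no measured step speaks to this change: the one step available is unreadable, and none of the three compounds gives a number to start from. On this basis no step beyond the usual scatter can be expected in either direction, and the most likely outcome for compound 4 is another limit. The estimate for compound 4 is 100000 nM, with a range from 30000 nM to 300000 nM. The step from compound 2 that this estimate means, a number no higher from compound 2 to compound 4 (the limit leaves the size open), is expected to be nothing beyond the scatter.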

Compound 4, half-maximal inhibitory concentration: > 100000 nM
Compound 4 gave a limit, no number; the forecaster's own chance of this, stated with the estimate: 85%; the middle value lies on the limit itself.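

Compound 4 is also only a limit, so the steps linking compound 1, compound 2 and compound 4 cannot be read in this assay: the limit of > 100000 nM in this assay, at which 4 of the 4 values shown sit.

The compounds shown leave open whether chloro or methylsulfonyl changes cytotoxicity at all, and what change to the shared core would give a real number in this assay.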